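A few compounds are considered here, and "the series" means these few. Any claim that something is new, unique, unknown or untested is made for them only; others in the source may bear on it.

Measured compounds in a functional assay on SW1573 cells (Homo sapiens) for inhibition, read by sulforhodamine B assay, with a stated time of 48 h; a lower number here means a stronger inhibitor of growth, a higher number a weaker inhibitor of growth:
compound 1 `COC(=O)[C@@]1(C)CCC=C2[C@@H]1CC[C@@H](C)[C@]2(C)Cc1c[nH]c2c(Br)cccc12` gives 14000 nM
compound 2 `COC(=O)[C@@]1(C)CCC=C2[C@@H]1CC[C@@H](C)[C@]2(C)Cc1c[nH]c2c(Cl)cccc12` gives 14000 nM

Among the measured compounds shown here, compound 2 stands level with compound 1 in this assay; the one measured step, no change at the digits printed from compound 1 to compound 2 (within the scatter), lies within the scatter. Compound 3 `COC(=O)[C@@]1(C)CCC=C2[C@@H]1CC[C@@H](C)[C@]2(C)Cc1c(C)[nH]c2c(Cl)cccc12` differs from compound 2 by methyl in place of hydrogen on an aromatic carbon. For the measured compounds named here, no measured step covers a methyl in place of hydrogen; the halogen swap from compound 1 to compound 2 does not bear on it. Going by the values given here, with no step to lean on, the expectation for this assay is no shift beyond the scatter, so the estimated step is no change at the digits printed from compound 2 to compound 3 (within the scatter). Compound 3 is expected to give about 14000 nM, within 5000 nM to 40000 nM.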

Compound 3, concentration for 50% growth inhibition: 19000 nM
Estimate against measurement, compound 3: 1.4-fold (0.13 log units) below, within the range that was stated.
By their numbers in this assay, from the lowest: compounds 1, 2 and 3 (each within the scatter of the next).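

In this assay, methyl in place of hydrogen on the aromatic carbon next to the ring nitrogen gives a 1.4-fold higher number from compound 2 to compound 3 (0.13 log units; within the scatter). This position, next to the ring atom that bears a large group, therefore takes a methyl with no shift beyond the scatter, something the halogen swap could not show. Nothing measured here speaks to a cause. Still open, as far as these compounds go, is whether a longer chain, an amine or a carboxylic acid at this position would move the number beyond the scatter.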